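The source may hold more compounds than are shown below. What is called first, only, known or untested is meant among the compounds shown, and "the series" means these compounds.

Compound 1 `COc1ccc(C(=O)/C=C/c2ccc(OCc3cn(Cc4ccccc4)nn3)cc2)cc1` is the starting point of this small set. In a functional assay on MCF7 cells (Homo sapiens) for inhibition, read by MTT assay, with a stated time of 48 h, tested at 10 uM (a lower number here means less inhibition of growth, a higher number more inhibition of growth at the concentration tested), compound 1 gives 70%. Compound 2 `COc1ccc(C(=O)/C=C/c2ccc(OCc3cn(Cc4ccc(Br)cc4)nn3)cc2)cc1` carries a bromine atom on the benzyl ring and gives 53% in this assay; the change is bromo in place of hydrogen on an aromatic carbon, and the step of a number 17 percentage points lower from compound 1 to compound 2 (beyond the scatter) shows that this addition lowered growth inhibition by a modest but real amount.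

Compound 3 `O=C(/C=C/c1ccc(OCc2cn(Cc3ccccc3)nn2)cc1)c1ccc([N+](=O)[O-])cc1` differs from compound 1 in the other end of the molecule: the change is nitro in place of methoxy on an aromatic carbon. In this assay compound 3 gives "not active" (no number reported), so no number is known for it, only that it did not inhibit growth to a reportable degree.

Compound 4 `O=C(/C=C/c1ccc(OCc2cn(Cc3ccccc3Br)nn2)cc1)c1ccc([N+](=O)[O-])cc1` is compound 3 with a bromine atom added: the change is bromo in place of hydrogen on an aromatic carbon. Within the data shown here, this is the same kind of change as the one from compound 1 to compound 2, but not the same, since in compound 2 the bromine sits para to a large group while in compound 4 it sits ortho to a large group. Compound 4 has not yet been tested.

Among the measured compounds shown here, because compound 3 gives "not active" (no number reported) and the only measured bromo step, a number 17 percentage points lower from compound 1 to compound 2 (beyond the scatter), went downward, compound 4 is expected to show little or no growth inhibition in this assay. The estimated value for compound 4 is 10%, with a plausible range from 0% to 30%; it may well again be reported only as not active.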

Compound 4, percent growth inhibition at one concentration: 43%
Compound 4: the middle estimate sits 33 percentage points below what was measured; the measured number lies above the stated range.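

In this assay compound 3 gives "not active" (no number reported) and compound 4 gives 43%, so the step between them has a number at only one end and cannot be read. The compounds shown leave open how a 2-bromobenzyl group compares with a plain benzyl group when both compounds have numerical values. Nothing shown here explains the result for compound 4.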